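Cytotoxicity of Four Related Compounds in HEL Cells

The source may hold more compounds than are shown below. What is called first, only, known or untested is meant among the compounds shown, and "the series" means these compounds.

Of the compounds shown here, three have been tested in a functional assay on HEL cells (Homo sapiens) for cytotoxicity (a higher number here means that more compound is tolerated, a lower number that less compound is tolerated), and a fourth awaits measurement. Compound 1 `CCCCC#Cc1cc2cn([C@@H]3O[C@H](CO)[C@@H](O)[C@H]3O)c(=O)nc2o1`, compound 2 `CCCCC#Cc1cc2cn([C@H]3C[C@H](O)[C@@H](CO)O3)c(=O)nc2o1` and compound 3 `CCCCCCC#Cc1cc2cn([C@H]3C[C@H](O)[C@@H](CO)O3)c(=O)nc2o1` were measured; compound 4 `CCCCCCC#Cc1cc2cn([C@@H]3O[C@H](CO)[C@@H](O)[C@@H]3O)c(=O)nc2o1` was not.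

For compound 1 the result is a limit of the assay, > 144000 nM. For compound 2 the result is likewise a limit, > 150000 nM. Compound 3 is the only one of the three to give a number, 138000 nM in this assay.

Compound 2 and compound 1 differ by hydroxy in place of hydrogen on a saturated ring carbon. The step that the two limits leave unreadable from compound 2 to compound 1 cannot be sized, because the limit of > 150000 nM in this assay, at which 1 of the 3 values shown sits, and because of the limit of > 144000 nM in this assay, at which 1 of the 3 values shown sits. Between compound 2 and compound 3 the step is an at least 1.0-fold lower number from compound 2 to compound 3 (0.03 log units; that floor lies within the scatter), so these two values show no difference that can be trusted.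

Compound 3 and compound 4 differ by hydroxy in place of hydrogen on a saturated ring carbon. This is the same change as from compound 2 to compound 1, at a place described in the same words, while the two cores differ by ethyl in place of hydrogen on a saturated chain carbon, four bonds along the chain from a triple-bonded carbon. The earlier occurrence of this change left both compounds at a limit and gave no readable size. The expectation for compound 4 therefore rests mainly on the value of compound 3 138000 nM and on the fact that all three measured values sit at or near the top of what was tested. The step from compound 3 to compound 4 is therefore expected to be small, a 1.0-fold higher number from compound 3 to compound 4 (0.01 log units; within the scatter). Compound 4 is estimated at 140000 nM, most likely between 70000 nM and 300000 nM.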

Compound 4, half-maximal cytotoxic concentration: > 53000 nM
Compound 4: only a limit was reported; the forecaster's own chance of this, stated with the estimate: 50%; the middle value lies beyond the limit too.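

Compound 3 and compound 4 yield no new step that can be read, because the result for compound 4 is a limit of the assay and not a number: the limit of > 53000 nM in this assay, at which 1 of the 4 values shown sits.

The compounds shown leave open whether hydroxy in place of hydrogen on a saturated ring carbon changes the number in this assay at all, as neither pair carrying this change gives a readable size.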